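This account rests on a few compounds, and the source may have more. Where it says the series, first, only, none or still open, it means among the compounds named here.

Measured in a functional assay on HL-60 cells (Homo sapiens) for antiproliferative activity, read by XTT assay, with a stated time of 72 h; a lower number here means a stronger inhibitor, a higher number a weaker inhibitor:
- compound 1 `COc1ncnc2c1c(-c1cc3ccccc3o1)cn2[C@@H]1O[C@H](CO)[C@@H](O)[C@H]1O`: 4470 nM
- compound 2 `CSc1ncnc2c1c(-c1ccoc1)cn2[C@@H]1O[C@H](CO)[C@@H](O)[C@H]1O`: 360 nM
- compound 3 `CSc1ncnc2c1c(-c1cccs1)cn2[C@@H]1O[C@H](CO)[C@@H](O)[C@H]1O`: 1130 nM

Compound 3, at 1130 nM, holds the middle place of the three. Compound 2 has the lower number, at 360 nM, and compound 1 has the higher, at 4470 nM. Both gaps lie beyond the scatter.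

Next in the series is compound 4 `C#Cc1cn([C@@H]2O[C@H](CO)[C@@H](O)[C@H]2O)c2ncnc(SC)c12`, with ethynyl in place of thiophen-2-yl on an aromatic carbon. The rest of the structure stays as in compound 3.

Among the measured compounds shown here, only one measured step touches this position: a 3.1-fold higher number from compound 2 to compound 3 (0.50 log units; beyond the scatter). For the measured compounds named here, it exchanges one five-membered aromatic ring for another, so it shows that the number in this assay responds to the group at this place, but no measured step replaces the ring with a group that has none. Compound 1 differs from compound 3 in more than one place and gives no clean comparison.

A modest step is therefore expected, of about the measured size and towards a lower number, though the direction is weakly supported. The estimated change is a 2.5-fold lower number from compound 3 to compound 4 (0.40 log units; beyond the scatter). For compound 4 the expected value is 450 nM, with an estimated range of 80 nM to 2500 nM.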

Compound 4, half-maximal inhibitory concentration: 50 nM
For compound 4 the middle estimate is 9.0-fold (0.95 log units) above the measured one, outside the stated range (below it).
By their numbers in this assay, from the lowest: compound 4; then compound 2; then compound 3; then compound 1.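

In this assay, a ring is not needed at this place on the five-membered aromatic ring: ethynyl, which has no ring and fewer heavy atoms than thiophen-2-yl, gives a 23-fold lower number from compound 3 to compound 4 (1.35 log units; beyond the scatter). The result is not tied to one ring, since ethynyl in place of furan-3-yl gives a 7.2-fold lower number from compound 2 to compound 4 (0.86 log units; beyond the scatter), and both steps run the same way and exceed the exchange of one ring for the other, a 3.1-fold higher number from compound 2 to compound 3 (0.50 log units; beyond the scatter). No measured data on these compounds account for the size or direction of these steps.

The compounds shown do not separate the triple bond from the small size of the group, a question that ethyl, vinyl or nitrile at this place would address, while a longer chain such as prop-1-ynyl or an ethynyl bearing an aryl group would show how much extension the position allows. Going by these compounds, both ethynyl steps also rest on a single remainder of the structure, so it remains open whether ethynyl has a similar effect alongside the methoxy group of compound 1.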